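Benzyl in place of cyclohexyl: working notes on the series

The compounds below may be only part of what the source reports. "The series", "measured", "known", "first", "only" and "open" are said of these compounds alone.

In a functional assay on UACC-62 cells (Homo sapiens) for inhibition, read by sulforhodamine B assay, with a stated time of 48 h, tested at 10 uM (on this read-out lower numbers stand for less inhibition and higher numbers for more inhibition at the one concentration tested (going by the name of the read-out)), the three measured compounds give the following:

compound 1, `c1ccc2c(-c3cn4ccnc4c(-c4ccc5ncn(C6CCCCC6)c5c4)n3)cccc2c1`: 16.7%
compound 2, `c1ccc(Cn2cnc3ccc(-c4nc(-c5cccc6ccccc56)cn5ccnc45)cc32)cc1`: 12.9%
compound 3, `c1cn2cc(-c3ccc4c(c3)ncn4C3CCCCC3)nc(-c3ccc4ncn(C5CCCCC5)c4c3)c2n1`: 29.3%

Compound 1 and compound 2 differ in one place only, by benzyl in place of cyclohexyl on an aromatic nitrogen. The step of a number 3.8 percentage points lower from compound 1 to compound 2 (within the scatter), and it is stated to lie within the scatter of repeated measurements, so no order between compound 1 and compound 2 is claimed.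

Compound 3 gives the highest number of the three in this assay; its gaps to compound 1 and to compound 2 are both stated to lie beyond the scatter. How the core of compound 3 differs from the core of compound 1 is not broken down here.

Compound 4, `c1ccc(Cn2cnc3ccc(-c4nc(-c5ccc6c(c5)ncn6C5CCCCC5)cn5ccnc45)cc32)cc1`, is not yet measured. It differs from compound 3 by benzyl in place of cyclohexyl on an aromatic nitrogen. Within the data shown here, this is the same change, at the same kind of place, as the one from compound 1 to compound 2.

Among the measured compounds shown here, the step from compound 3 to compound 4 is expected to be small, a number 4.3 percentage points lower from compound 3 to compound 4 (within the scatter), because the only measured instance of this change, a number 3.8 percentage points lower from compound 1 to compound 2 (within the scatter), stayed within the scatter. On that basis the expected value for compound 4 in this assay is estimated at 25%, with a plausible range from 10% to 40%; the range is wide because it rests on a single measured step, a number 3.8 percentage points lower from compound 1 to compound 2 (within the scatter), and on one reference value for compound 3.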

Compound 4, a percentage reported as inhibition, at one concentration (the size of the read-out at that concentration, not a potency): -31.2%
For compound 4 the middle estimate is 56.2 percentage points above the measured one; the measured number lies below the stated range.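

In this assay, benzyl in place of cyclohexyl on an aromatic nitrogen does not carry over from one core to another as a step of fixed size, and the two measured instances differ: the same change on two cores in this assay, a number 3.8 percentage points lower (within the scatter) from compound 1 to compound 2 and a number 60.5 percentage points lower (beyond the scatter) from compound 3 to compound 4, 56.7 percentage points apart, beyond the scatter of two such steps

The small step on the core of compound 1 therefore gives no safe guide to the same change on the core of compound 3, where the result is a number 60.5 percentage points lower from compound 3 to compound 4 (beyond the scatter), with compound 4 at -31.2%. This shows that the outcome of the change depends on the compound that carries it, but it rests on two pairs only: it gives no cause for the difference, no rule for any further core, and no account of what a negative number means for compound 4.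

The compounds shown leave open whether other groups on the same aromatic nitrogen, such as a longer alkyl chain, a chain ending in an amine or one ending in a carboxylic acid, would give a small step on both cores or a large step on one. Also open, as far as these compounds go, is whether the difference between the two steps would appear in a different cell line or at a different concentration.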